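This account rests on a few compounds, and the source may have more. Where it says the series, first, only, none or still open, it means among the compounds named here.

Measured so far:
compound 1 `COc1cc2c(Nc3nc4ccc(C(=O)Nc5c(C)cccc5C)cc4s3)ncnc2cc1OCCCN1CCCCC1` — in a functional assay on A549 cells (Homo sapiens) for cytotoxicity, read by WST assay, with a stated time of 72 h (a higher number here means a weaker inhibitor, a lower number a stronger inhibitor), compound 1 gives only a limit, > 100000 nM.
compound 2 `COc1cc2c(Nc3nc4ccc(C(=O)Nc5c(C)cccc5C)cc4s3)ncnc2cc1OCCCN1CCC(C)CC1` — compound 2 gives 89700 nM.
compound 3 `COc1cc2c(Nc3nc4ccc(C(=O)Nc5c(C)cc(C)cc5C)cc4s3)ncnc2cc1OCCCN1CCCCC1C` — compound 3 gives 5800 nM.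

Compound 3 holds the lowest of the two numbers, the gap to compound 2 lying well beyond the scatter; compound 1 is known only as the limit (the limit of > 100000 nM in this assay, at which 1 of the 3 values shown sits). Compound 4 `COc1cc2c(Nc3nc4ccc(C(=O)Nc5c(C)cccc5C)cc4s3)ncnc2cc1OCCCN1CCCCC1C` differs from compound 3 by hydrogen in place of methyl on an aromatic carbon. Going by the values given here, the only measured step, an at least 1.1-fold lower number from compound 1 to compound 2 (0.04 log units; that floor lies within the scatter), concerns a methyl on a saturated ring carbon and sits within the scatter, so it does not speak to an aromatic methyl. Compound 4 shares its 2,6-dimethylphenyl with compound 2 and its other ring with compound 3, each a pair without a measured step. Compound 4 is expected to give 25000 nM, within 8000 nM to 90000 nM. The expected step is a 4.3-fold higher number from compound 3 to compound 4 (0.63 log units; beyond the scatter).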

Compound 4, half-maximal inhibitory concentration: 75700 nM
Compound 4: the middle estimate sits 3.0-fold (0.48 log units) below what was measured; the range from low to high includes it.
By their numbers in this assay, from the lowest: compound 3; then compounds 4 and 2 (each within the scatter of the next). At a limit, above all of these: compound 1.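

In this assay, the methyl on the aromatic carbon para to a large group carries a large effect: going from 2,4,6-trimethylphenyl to 2,6-dimethylphenyl gives a 13-fold higher number from compound 3 to compound 4 (1.12 log units; beyond the scatter). With 2,6-dimethylphenyl in place, 2-methylpiperidin-1-yl in place of 4-methylpiperidin-1-yl on a saturated chain carbon gives a 1.2-fold lower number from compound 2 to compound 4 (0.07 log units; within the scatter), so the two are not told apart. Methyl in place of hydrogen on a saturated ring carbon gives an at least 1.3-fold lower number from compound 1 to compound 4 (0.12 log units; that floor lies within the scatter), a step that cannot be read. Compound 1 stands at a limit: the limit of > 100000 nM in this assay, at which 1 of the 4 values shown sits.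

Open, from the compounds shown here alone, is whether a chlorine or a methoxy group on that aromatic carbon would match the methyl. Also open, going by these compounds, is whether the methyl step holds with 4-methylpiperidin-1-yl on the chain.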